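This account rests on a few compounds, and the source may have more. Where it says the series, first, only, none or still open, it means among the compounds named here.

In a physicochemical assay for lipophilicity, at pH 7.4 (on this read-out higher numbers stand for higher lipophilicity and lower numbers for lower lipophilicity), compound 3 `Cc1cc(C(=O)NCc2cccnc2)nn1Cc1cc(Cl)ccc1OCc1ccccc1` is reported as > 3.7, which is a limit and not a number. Compound 1 `CNC(=O)c1cc(C)n(Cc2cc(Cl)ccc2OCc2ccccc2)n1` gives > 3.7, again a limit. Among the measured compounds shown here, compound 2 `Cc1cc(C(=O)Nc2c(F)cccc2F)nn1Cc1cc(Cl)ccc1OCc1ccccc1` provides the only actual number, 3.7. For the measured compounds named here, the series so far is therefore defined by the limit of > 3.7 in this assay, at which 2 of the 3 values shown sit.

Compound 4 `Cc1cc(NC(=O)CC(C)(C)C)nn1Cc1cc(Cl)ccc1OCc1ccccc1` has (neopentylcarbonyl)amino in place of ((pyridin-3-yl)methyl)carbamoyl on an aromatic carbon, and the full change is (neopentylcarbonyl)amino in place of ((pyridin-3-yl)methyl)carbamoyl on an aromatic carbon.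

Three measured steps offer some guidance, all of them changes to the group on the amide-type nitrogen. They are a number no higher from compound 1 to compound 2 (the limit leaves the size open), a step that the two limits leave unreadable from compound 1 to compound 3 and a number no lower from compound 2 to compound 3 (the limit leaves the size open). None has a readable size, and none replaces the carbamoyl group itself, so no measured size can be carried over to this change. Going by the values given here, the best anchor is compound 2 at 3.7, the one number available. No step beyond the scatter is therefore expected in this assay, and no clear direction can be given. The estimated step is a step that the limit leaves unreadable from compound 3 to compound 4, and it carries the uncertainty of starting from a limit. For compound 4 the expected value is 3.9, with an estimated range from 3.5 to 4.4.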

Compound 4, distribution coefficient: > 3.7
Compound 4 gave a limit, no number; the forecaster's own chance of this, stated with the estimate: 70%; the middle value is on the limit's open side.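

The change to compound 4 is the first one shown that replaces the carbamoyl group itself on the aromatic carbon, so that the amide nitrogen, not the carbonyl carbon, is now the atom bound to the ring. Among the compounds shown here, the only step with a direction is a number no lower from compound 2 to compound 4 (the limit leaves the size open), while the steps to compound 4 from compound 1 and from compound 3 cannot be read, as both ends of each are limits. Turning the amide around thus adds one more limit, and compound 2 remains the only compound with an actual number: the limit of > 3.7 in this assay, at which 3 of the 4 values shown sit.

From the compounds shown here alone, how far compound 4 really differs from compound 1 or compound 3 in this assay stays open, as does any comparison between the two amide orientations. Also open, going by these compounds, is whether a carboxylic acid or an amine on this aromatic carbon would give a number instead of a limit.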